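This account rests on a few compounds, and the source may have more. Where it says the series, first, only, none or still open, it means among the compounds named here.

Among the compounds with values here, compound 2 `NS(=O)(=O)NCCC1CCN(c2cc(-c3ccc(Cl)cc3)ncn2)CC1` gives 45200 nM in a functional assay on M21 cells (Homo sapiens) for antiproliferative activity, read by sulforhodamine B assay, with a stated time of 48 h (a lower number here means a stronger inhibitor of growth, a higher number a weaker inhibitor of growth), the higher of the two numbers known, while compound 1 `COC(=O)c1ccc(-c2cc(N3CCC(CNS(N)(=O)=O)CC3)ncn2)cc1` gives 14100 nM in this assay. Compound 3 `COC(=O)c1ccc(-c2cc(N3CCC(CCNS(N)(=O)=O)CC3)ncn2)cc1` is not yet measured. It differs from compound 2 by methoxycarbonyl in place of chloro on an aromatic carbon. Within the data shown here, no step between measured compounds covers this swap, so the size is open; a move toward a lower number is expected, of moderate size, because compound 1, which also carries the methoxycarbonyl group, gives 14100 nM. Compound 3 is therefore estimated at 18000 nM, range 6000 nM to 50000 nM, an expected step of a 2.5-fold lower number from compound 2 to compound 3 (0.40 log units; beyond the scatter).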

Compound 3, concentration for 50% growth inhibition: 19600 nM
Compound 3: the middle estimate sits 1.1-fold (0.04 log units) below what was measured; measured number inside the range.
By their numbers in this assay, from the lowest: compounds 1 and 3 (each within the scatter of the next); then compound 2.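

In this assay, methoxycarbonyl in place of chloro on the aromatic carbon para to a large group gives a 2.3-fold lower number from compound 2 to compound 3 (0.36 log units; beyond the scatter), so this position responds to the swap, though only modestly. With methoxycarbonyl present, (sulfamoylamino)methyl in place of sulfamoylamino gives a 1.4-fold higher number from compound 1 to compound 3 (0.14 log units; within the scatter), which lies within the scatter, so the two chains are not told apart here. Nothing available explains either result. The compounds shown leave open how a carboxylic acid or a primary amide would compare at this aromatic carbon, and whether a longer chain would change the number.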